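Urea alkyl change in the diaryl ether sulfonylurea pair

The source may hold more compounds than are shown below. What is called first, only, known or untested is meant among the compounds shown, and "the series" means these compounds.

Compound 2 `CC(C)NC(=O)NS(=O)(=O)c1cc(C#N)ccc1Oc1ccc(Br)cc1` gives 9470 nM in a functional assay on HEK293 cells for antagonist activity at thromboxane A2 receptor (Homo sapiens), read by fluorescence and calcium flux (a higher number here means a weaker inhibitor, a lower number a stronger inhibitor), the higher of the two numbers available; compound 1 `Cc1ccc(Oc2ccc(C#N)cc2S(=O)(=O)NC(=O)NC(C)(C)C)cc1` gives 750 nM in this assay, and since the two structures differ in more than one place, only the two values themselves can be read from that gap. Compound 3 `CC(C)(C)NC(=O)NS(=O)(=O)c1cc(C#N)ccc1Oc1ccc(Br)cc1` carries methyl in place of hydrogen on a saturated chain carbon bound to an amide-type nitrogen and two saturated chain carbons relative to compound 2. Going by the values given here, no measured pair isolates this single change. A modest step towards a lower number in this assay is expected, of about a 2.7-fold lower number from compound 2 to compound 3 (0.43 log units; beyond the scatter). Compound 3 is accordingly estimated at 3500 nM, with a range from 1200 nM to 10000 nM.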

Compound 3, half-maximal inhibitory concentration: 5880 nM
Compound 3: the middle estimate sits 1.7-fold (0.23 log units) below what was measured; low and high end bracket the measured number.
By their numbers in this assay, from the lowest: compound 1; then compounds 3 and 2 (each within the scatter of the next).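

With bromo held on the shared core, isopropyl to tert-butyl gives no separable difference in this assay (a 1.6-fold lower number from compound 2 to compound 3 (0.21 log units; within the scatter)), so these two alkyl groups are not told apart at this position. Going by these compounds alone, with tert-butyl held, bromo in place of methyl on an aromatic carbon gives the first single-place step at that carbon (a 7.8-fold higher number from compound 1 to compound 3 (0.89 log units; beyond the scatter)), and here methyl carries the lower number. No evidence at hand bears on either step.

Still open, from the compounds shown here alone, is how a cyclohexyl group or a longer chain in place of tert-butyl would read. Also open, going by these compounds, is how chloro or methoxy would read on that aromatic carbon.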